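Adding an Acetyl Group: What to Expect for Compound 4

This account rests on a few compounds, and the source may have more. Where it says the series, first, only, none or still open, it means among the compounds named here.

Compound 1 `COc1ccc(/C(=C\c2c[nH]c3ccc(OCc4ccccc4)cc23)C(=O)O)cc1` was entered in a functional assay on LNCaP cells (Homo sapiens) for cytotoxicity, read by MTT assay, with a stated time of 72 h (a higher number here means a weaker inhibitor, a lower number a stronger inhibitor), where compound 1 gives "not determined" (no result reported), so it stands on no number here. Compound 4 `COc1ccc(/C(=C\c2cn(C(C)=O)c3ccc(OCc4ccccc4)cc23)C(=O)O)cc1` differs from compound 1 in one place: acetyl in place of hydrogen on an aromatic nitrogen. Two related compounds that already carry this acetyl group have been measured. Compound 2 `COc1ccc(OC)c(/C(=C\c2cn(C(C)=O)c3ccc(OCc4ccccc4)cc23)C(=O)O)c1` gives 44100 nM in this assay, and compound 3 `COc1cc(OC)cc(/C(=C\c2cn(C(C)=O)c3ccc(OCc4ccccc4)cc23)C(=O)O)c1` gives 26100 nM. Among the measured compounds shown here, the one measured step, a 1.7-fold lower number from compound 2 to compound 3 (0.23 log units; within the scatter), alters a different part of the molecule and so says nothing about exchanging hydrogen for acetyl on the aromatic nitrogen. For the measured compounds named here, with no value for compound 1 and no step that bears on the change, neither the direction nor the size of the step from compound 1 to compound 4 can be read from these data. What the data do show is that both acetyl-bearing compounds sit in a similar weak range in this assay. Compound 4 is therefore expected to land near them, at an estimated 32000 nM with a range from 8000 nM to 120000 nM. This expectation rests on compound 2 with 44100 nM and on compound 3 with 26100 nM.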

Compound 4, half-maximal inhibitory concentration: 85000 nM
Compound 4: middle estimate off by 2.7-fold (0.42 log units), on the low side, within the range that was stated.
By their numbers in this assay, from the lowest: compounds 3, 2 and 4 (each within the scatter of the next, the first and the last beyond it).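

On the double-bonded chain carbon, the choice of aryl group can move the result in this assay: exchanging 3,5-dimethoxyphenyl for 4-methoxyphenyl gives a 3.3-fold higher number from compound 3 to compound 4 (0.51 log units; beyond the scatter) and so reaches past the scatter. Among the compounds shown here, exchanging 2,5-dimethoxyphenyl for 4-methoxyphenyl gives a 1.9-fold higher number from compound 2 to compound 4 (0.28 log units; within the scatter) and does not, so only one of the two swaps to 4-methoxyphenyl is a clear change. No measurement on hand offers an explanation for this difference between the two swaps.

From the compounds shown here alone, compound 1 has no number, so the step from hydrogen to acetyl on the aromatic nitrogen cannot be read, and the effect of that acetyl remains unknown. Also open, going by these compounds, is whether an amine on the phenyl ring at the chain carbon, or a longer acyl chain on the aromatic nitrogen, would shift the number.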